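A few compounds are considered here, and "the series" means these few. Any claim that something is new, unique, unknown or untested is made for them only; others in the source may bear on it.

Compound 1, `Cc1cc(C(=O)NC(C)C)nn1Cc1cc(Cl)ccc1OCc1ccccc1`, 126 nM.
Compound 2, `Cc1cc(C(=O)Nc2ccccc2)nn1Cc1cc(Cl)ccc1OCc1ccccc1`, 39.8 nM.
Compound 3, `Cc1cc(C(=O)Nc2c(F)cccc2F)nn1Cc1cc(Cl)ccc1OCc1ccccc1`, 10 nM.

These three compounds share one core and differ only in the group attached to the amide-type nitrogen. In an assay on CHO-K1 cells for displacement of a labelled ligand from prostaglandin E2 receptor EP1 subtype (Homo sapiens) (a higher number here means a weaker inhibitor, a lower number a stronger inhibitor), compound 3 gives the lowest number of the three: compound 2 sits a 4.0-fold lower number from compound 2 to compound 3 (0.60 log units; beyond the scatter) away, and compound 1 further still, a 13-fold lower number from compound 1 to compound 3 (1.10 log units; beyond the scatter) away. Compound 4, `Cc1cc(C(=O)NCc2ccncc2)nn1Cc1cc(Cl)ccc1OCc1ccccc1`, has not yet been measured. It differs from compound 3 in one place: (pyridin-4-yl)methyl in place of 2,6-difluorophenyl on an amide-type nitrogen.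

Among the compounds with values here, two measured steps bear on this change. Going from an isopropyl group to a phenyl group gave a 3.2-fold lower number from compound 1 to compound 2 (0.50 log units; beyond the scatter), and adding two fluorines to that phenyl gave a further a 4.0-fold lower number from compound 2 to compound 3 (0.60 log units; beyond the scatter). Within the data shown here, compound 4 gives up both the fluorines and the direct attachment of the aromatic ring, which now hangs from a methylene; no measured compound carries such a group, so the comparison is only approximate. The expectation is that compound 4 loses much of the gain seen in compound 3, with a step of a 10-fold higher number from compound 3 to compound 4 (1.00 log units; beyond the scatter) in this assay. The estimate for compound 4 is therefore 100 nM, with a range from 30 nM to 400 nM.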

Compound 4, half-maximal inhibitory concentration: 79.4 nM
The estimate for compound 4 lay 1.3-fold (0.10 log units) above the measured number; low and high end bracket the measured number.
By their numbers in this assay, from the lowest: compound 3; then compounds 2, 4 and 1 (each within the scatter of the next, the first and the last beyond it).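

In this assay the 2,6-difluorophenyl group on the amide-type nitrogen now stands out against a third kind of group, since (pyridin-4-yl)methyl in its place gives a clear rise in the number (a 7.9-fold higher number from compound 3 to compound 4 (0.90 log units; beyond the scatter)), and compound 3 remains the strongest of the four. The other two comparisons show something new: neither the step to phenyl (a 2.0-fold higher number from compound 2 to compound 4 (0.30 log units; within the scatter)) nor the step to isopropyl (a 1.6-fold lower number from compound 1 to compound 4 (0.20 log units; within the scatter)) goes beyond the scatter, so this position accepts a ring nitrogen on a methylene without a result that can be told apart from either group, even though phenyl and isopropyl differ clearly from each other. Nothing available explains these numbers.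

Compound 4 changes the ring and its attachment at once. The data cannot tell the ring nitrogen, the missing fluorines and the methylene apart; a benzyl group, or a pyridin-4-yl group joined directly to the amide nitrogen, would help separate them. From the compounds shown here alone, whether a (2,6-difluorophenyl)methyl group would keep the low number of compound 3 also remains unknown.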